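Replacing the Pyridinyl Amine Partner: an Expected Value

The source may report more compounds than this note shows. Statements on the series, on what has been measured and on what is new or still open speak of the compounds shown alone.

Measured compounds:
- Compound 1, `CCCCS(=O)(=O)Nc1cc(-c2ccc3ncnc(Nc4ccc(OCCO)nc4)c3c2)cnc1OC`, gives > 20000 nM in a functional assay on HCT-116 cells (Homo sapiens) for antiproliferative activity, read by sulforhodamine B assay, with a stated time of 72 h (a lower number here means a stronger inhibitor, a higher number a weaker inhibitor), a limit of the assay and not a number.
- Compound 2, `COc1ncc(-c2ccc3ncnc(Nc4ccc(OCCO)nc4)c3c2)cc1NS(C)(=O)=O`, gives 5360 nM in this assay.

Compound 2 holds the only number shown in this assay; the other value shown is a limit. Within the data shown here, the one measured step, an at least 3.7-fold lower number from compound 1 to compound 2 (0.57 log units; beyond the scatter), concerns the chain on the sulfonyl group, which both compound 2 and compound 3 keep.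

Compound 3, `COC(=O)CCn1cc(Nc2ncnc3ccc(-c4cnc(OC)c(NS(C)(=O)=O)c4)cc23)cn1`, differs from compound 2 in another place: 1-(2-(methoxycarbonyl)ethyl)-1H-pyrazol-4-yl in place of 6-(2-hydroxyethoxy)pyridin-3-yl on a nitrogen on an aromatic ring. Among the measured compounds shown here, no measured step touches this position, so the direction of the change cannot be read from the data. In the absence of such evidence, compound 3 is expected to land close to compound 2, a step of a 1.1-fold lower number from compound 2 to compound 3 (0.03 log units; within the scatter) at most near the scatter. The estimate for compound 3 in this assay is 5000 nM, within a range of 1200 nM to 18000 nM.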

Compound 3, half-maximal inhibitory concentration: 970 nM
The estimate for compound 3 lay 5.2-fold (0.71 log units) above the measured number, outside the stated range (below it).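

In this assay, 1-(2-(methoxycarbonyl)ethyl)-1H-pyrazol-4-yl in place of 6-(2-hydroxyethoxy)pyridin-3-yl on the nitrogen gives a 5.5-fold lower number from compound 2 to compound 3 (0.74 log units; beyond the scatter). The sulfonyl chain is therefore not the only place that moves this number: the group on this nitrogen matters too, and a five-membered aromatic ring can stand here without loss of activity. The swap changes the ring and its side chain together, and nothing measured here explains the gain.

The compounds shown leave open whether the ring or the side chain carries the step. Keeping the same ring while replacing the methoxycarbonyl end with a carboxylic acid or an amine, or using a longer chain, would begin to separate the two.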